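A few compounds are considered here, and "the series" means these few. Any claim that something is new, unique, unknown or untested is made for them only; others in the source may bear on it.

Working notes on the series. Compound 1 `FC(F)(F)c1ccc(CN2CCN(Cc3cc(-c4ccc(OCc5ccccc5Cl)cc4)on3)CC2)cc1` and compound 2 `Fc1ccccc1COc1ccc(-c2cc(CN3CCN(Cc4ccc(C(F)(F)F)cc4)CC3)no2)cc1` share one core and differ only in the halogen on the benzyloxy ring. In a functional assay on Mahlavu cells (Homo sapiens) for antiproliferative activity, read by sulforhodamine B assay, with a stated time of 72 h (on this read-out lower numbers stand for stronger inhibition and higher numbers for weaker inhibition), compound 1 gives 3200 nM, and in this assay compound 2 gives 3100 nM. The step of a 1.0-fold lower number from compound 1 to compound 2 (0.01 log units; within the scatter) is within the scatter. Compound 2 holds the lower of the two numbers, but its gap to compound 1 is within the scatter, so no order between them can be stated. Compound 3 `Fc1ccc(COc2ccc(-c3cc(CN4CCN(Cc5ccc(C(F)(F)F)cc5)CC4)no3)cc2)cc1` is not yet measured; it differs from compound 2 by 4-fluorophenyl in place of 2-fluorophenyl on a saturated chain carbon bound to an oxygen on an aromatic ring. Among the measured compounds shown here, the only measured step touching that part of the molecule, the halogen swap in the step already given, was flat, and no measured step moves a substituent around that ring. Given the flat step a 1.0-fold lower number from compound 1 to compound 2 (0.01 log units; within the scatter), the expectation for compound 3 is a 1.1-fold higher number from compound 2 to compound 3 (0.05 log units; within the scatter) in this assay. Compound 3 is estimated at 3500 nM, within a range of 1500 nM to 8000 nM.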

Compound 3, half-maximal inhibitory concentration: 3100 nM
Beside the measured number, compound 3's estimate is 1.1-fold (0.05 log units) above it; the range from low to high includes it.
By their numbers in this assay, from the lowest: compounds 2, 3 and 1 (each within the scatter of the next).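

In this assay, 4-fluorophenyl in place of 2-fluorophenyl on a saturated chain carbon bound to an oxygen on an aromatic ring gives no change at the digits printed from compound 2 to compound 3 (within the scatter); unlike the earlier step, which exchanged one halogen for another, this step changes where the fluorine sits on the ring. Changing the halogen and its place together, 4-fluorophenyl in place of 2-chlorophenyl, gives a 1.0-fold lower number from compound 1 to compound 3 (0.01 log units; within the scatter), so neither kind of change, alone or combined, moves the number beyond the scatter, and the three compounds cannot be put in order. No measured evidence bears on why the numbers stay level.

As far as these compounds go, all three compounds carry one halogen on this ring, so it remains open whether a group of another kind there, such as methoxy, nitrile or an amine, would also leave the number level. Equally open, from the compounds shown here alone, is whether a longer chain in place of the 4-fluorobenzyl group would do the same.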